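The source may report more compounds than this note shows. Statements on the series, on what has been measured and on what is new or still open speak of the compounds shown alone.

Three compounds share one core and differ only in the aryl group on a saturated chain carbon bound to an amine nitrogen. In a functional assay on BXPC-3 cells (Homo sapiens) for inhibition, read by MTT assay, with a stated time of 72 h (a lower number here means a stronger inhibitor of growth, a higher number a weaker inhibitor of growth), compound 1 `CC(C)(C)c1ccc(CNCCCNS(=O)(=O)c2cc(C(F)(F)F)cc(C(F)(F)F)c2)cc1` gives 1400 nM, and compound 2 `O=S(=O)(NCCCNCc1ccc(Cl)c(Cl)c1)c1cc(C(F)(F)F)cc(C(F)(F)F)c1` gives 1400 nM. Compound 3 `COc1ccc(CNCCCNS(=O)(=O)c2cc(C(F)(F)F)cc(C(F)(F)F)c2)cc1OC` has the highest number of the three, giving 13000 nM in this assay; the steps of a 9.3-fold higher number from compound 1 to compound 3 (0.97 log units; beyond the scatter) and a 9.3-fold higher number from compound 2 to compound 3 (0.97 log units; beyond the scatter) both went beyond the scatter, while no change at the digits printed from compound 1 to compound 2 (within the scatter). Compound 4 `O=S(=O)(NCCCNCc1ccc(Cl)c(C(F)(F)F)c1)c1cc(C(F)(F)F)cc(C(F)(F)F)c1` carries the change (4-chloro-3-(trifluoromethyl)phenyl in place of 3,4-dimethoxyphenyl on a saturated chain carbon bound to an amine nitrogen). Because the step of a 9.3-fold higher number from compound 2 to compound 3 (0.97 log units; beyond the scatter) accompanied the exchange of 3,4-dichlorophenyl for 3,4-dimethoxyphenyl, the reverse exchange toward 4-chloro-3-(trifluoromethyl)phenyl is expected to lower the number by a similar amount. Compound 4 is thus expected to show a step of an 8.7-fold lower number from compound 3 to compound 4 (0.94 log units; beyond the scatter). Compound 4 is therefore estimated at 1500 nM, within a range from 500 nM to 4500 nM.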

Compound 4, concentration for 50% growth inhibition: 7800 nM
The estimate for compound 4 lay 5.2-fold (0.72 log units) below the measured number; measured number above the stated range.
By their numbers in this assay, from the lowest: compounds 1 and 2 (each within the scatter of the next); then compounds 4 and 3 (each within the scatter of the next).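

In this assay, a single exchange on the ring matters: trifluoromethyl in place of chloro on an aromatic carbon gives a 5.6-fold higher number from compound 2 to compound 4 (0.75 log units; beyond the scatter). The exchange against the tert-butyl ring gives a 5.6-fold higher number from compound 1 to compound 4 (0.75 log units; beyond the scatter), whereas the exchange against the dimethoxy ring gives only a 1.7-fold lower number from compound 3 to compound 4 (0.22 log units; within the scatter). A chloro group on the ring is thus not enough to keep the number at the level of compound 2. No measurement at hand explains this shift. Also open, on these data alone, is how a ring carrying a nitrile or an amine would behave at this position.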